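Two Chlorines on the Sulfonyl Phenyl: an Expected Shift

The source may hold more compounds than are shown below. What is called first, only, known or untested is meant among the compounds shown, and "the series" means these compounds.

Compound 1, `CC1CCN(c2c(S(=O)(=O)c3ccccc3)cnc3ccc(F)cc23)CC1`, gives 40% in an assay on isolated protein for displacement of a labelled ligand from metabotropic glutamate receptor 5 (Homo sapiens), with a stated time of 60 min, tested at 1 uM; a lower number here means less inhibition, a higher number more inhibition at the concentration tested (going by the name of the read-out).
Compound 2, `CC1CCN(c2c(S(=O)(=O)c3ccccc3)cnc3ccc(Cl)cc23)CC1`, gives 59% in this assay.

Compound 1 stands lowest of the two measured numbers; its nearest neighbour is compound 2, which differs from it by a number 19 percentage points higher from compound 1 to compound 2 (beyond the scatter), the change being chloro in place of fluoro on an aromatic carbon of the shared core.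

Compound 3, `CC1CCN(c2c(S(=O)(=O)c3ccc(Cl)c(Cl)c3)cnc3ccc(F)cc23)CC1`, has not been measured. It differs from compound 1 by 3,4-dichlorophenyl in place of phenyl on a sulfonyl sulfur. No measured step alters the phenyl on the sulfonyl sulfur, so nothing shown bears directly on this change. Among the measured compounds shown here, the only measured step, chloro for fluoro elsewhere in the molecule, moved this assay by a number 19 percentage points higher from compound 1 to compound 2 (beyond the scatter); it speaks for chlorine at least not lowering the read-out, but it sits on a different ring and is taken only as a loose hint.

Compound 3 is therefore expected to show a modest rise, a number 15 percentage points higher from compound 1 to compound 3 (beyond the scatter), with wide uncertainty. The estimate for compound 3 in this assay is 55%, expected to fall between 30% and 80%.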

Compound 3, a percentage reported as inhibition, at one concentration (the size of the read-out at that concentration, not a potency): 91%
The estimate for compound 3 lay 36 percentage points below the measured number; the whole stated range lies below it.
By their numbers in this assay, from the lowest: compound 1; then compound 2; then compound 3.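

Putting 3,4-dichlorophenyl in place of phenyl on a sulfonyl sulfur gives a number 51 percentage points higher from compound 1 to compound 3 (beyond the scatter) in this assay, which shows that this position, untouched by the earlier step, can move the read-out a long way. This step is classed as large, whereas the step of chloro in place of fluoro, a number 19 percentage points higher from compound 1 to compound 2 (beyond the scatter), is classed as modest, and compound 3 reaches 91% with the fluoro of compound 1 still in place, so the change on the sulfonyl phenyl alone is enough to produce this rise. Nothing available explains why the step is so large, and the result stands here as an observation only.

The compounds shown leave open whether both chlorines are needed or one would do, as neither 3-chlorophenyl nor 4-chlorophenyl stands among them, and whether other groups at this place, such as 3,4-dimethoxyphenyl or a pyridine ring, would give a similar number. They also leave open whether the rise on the sulfonyl phenyl would carry over to the chloro compound 2, and, with a read-out taken at one concentration, how potent compound 3 actually is.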